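The compounds below may be only part of what the source reports. "The series", "measured", "known", "first", "only" and "open" are said of these compounds alone.

Of the compounds shown here, three built on one shared core have been tested in an assay on isolated protein for inhibition of aldehyde dehydrogenase 1A1 (Homo sapiens), read by spectrophotometry, tested at 10 uM; a lower number here means less inhibition, a higher number more inhibition at the concentration tested (going by the name of the read-out). Compound 1 `Cc1cccc(Cn2c(CN3CCN(C(=O)C4CCCCC4)CC3)nc3ccccc32)c1` gives 31.9%. Compound 2 `Cc1cccc(Cn2c(CN3CCN(C(=O)c4cccnc4)CC3)nc3ccccc32)c1` gives 24.5%, and compound 3 `Cc1cccc(Cn2c(CN3CCN(C(=O)c4ccncc4)CC3)nc3ccccc32)c1` gives 20.6%. Compound 3 holds the lowest of the three numbers: its nearest neighbour is compound 2, and the step of a number 3.9 percentage points lower from compound 2 to compound 3 (within the scatter) lies within the scatter, while the step of a number 11.3 percentage points lower from compound 1 to compound 3 (beyond the scatter) lies beyond it.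

Compound 4 `Cc1cccc(Cn2c(CN3CCN(C(=O)c4ccco4)CC3)nc3ccccc32)c1` has not yet been measured. It differs from compound 3 in one place: furan-2-yl in place of pyridin-4-yl on a carbonyl carbon.

The measured steps that bear on this change all swap the group on the same carbonyl carbon. The step of a number 7.4 percentage points lower from compound 1 to compound 2 (within the scatter) lies within the scatter, the step of a number 11.3 percentage points lower from compound 1 to compound 3 (beyond the scatter) is a modest drop beyond it, and the step of a number 3.9 percentage points lower from compound 2 to compound 3 (within the scatter), between two pyridyl rings, lies within the scatter. Swapping one small aromatic ring for another on this carbon has so far made little difference, so the step of a number 2.4 percentage points higher from compound 3 to compound 4 (within the scatter) is expected to stay within the scatter. Compound 4 is therefore estimated at 23% in this assay , with an expected range from 12% to 36%.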

Compound 4, a percentage reported as inhibition, at one concentration (the size of the read-out at that concentration, not a potency): 73.2%
Compound 4: the middle estimate sits 50.2 percentage points below what was measured, and the stated range ends below it.
By their numbers in this assay, from the lowest: compounds 3, 2 and 1 (each within the scatter of the next, the first and the last beyond it); then compound 4.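

Going by these compounds alone, on this carbonyl carbon, the earlier compounds made a swap of one small aromatic ring for another look minor in this assay, but furan-2-yl breaks that picture, with the steps of a number 52.6 percentage points higher from compound 3 to compound 4 (beyond the scatter), a number 48.7 percentage points higher from compound 2 to compound 4 (beyond the scatter) and a number 41.3 percentage points higher from compound 1 to compound 4 (beyond the scatter), all large. The change is also not one that simple counts would flag: pyridin-4-yl and furan-2-yl each carry one hetero atom and one hydrogen-bond acceptor, and they differ mainly in ring size and in having nitrogen or oxygen as that hetero atom. Nothing available explains why this ring stands so far apart from the other groups.

Open, going by these compounds, is whether the higher number goes with the five-membered ring or with its oxygen, which a thiophen-2-yl or pyrrol-2-yl group on the same carbon could help separate. Furan-3-yl could show whether the point of attachment on the furan ring matters as well.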